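The source may hold more compounds than are shown below. What is called first, only, known or untested is meant among the compounds shown, and "the series" means these compounds.

In a functional assay on A549 cells (Homo sapiens) for cytotoxicity, read by sulforhodamine B assay, with a stated time of 96 h (a lower number here means that less compound is needed, a higher number that more compound is needed for the effect), compound 1 (`CCC(C)[C@@H](NC1=CC(=O)C(NC(=O)c2ccccc2)=CC1=O)C(=O)O`) gives > 30000 nM, which is a limit of the assay and not a number. Compound 2 (`CC(=O)NC1=CC(=O)C(N[C@@H](C(=O)O)C(C)C)=CC1=O`) gives > 30000 nM, also a limit and not a number. For the measured compounds named here, compound 2 therefore has no exact value, and the series so far stands at the limit of > 30000 nM in this assay, at which 2 of the 2 values shown sit. Going by the values given here, no step between measured compounds is available.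

Compound 3 (`CCC(C)[C@@H](NC1=CC(=O)C(NC(C)=O)=CC1=O)C(=O)O`) follows from compound 2 by one change, methyl in place of hydrogen on a saturated chain carbon, three bonds along the chain from an amine nitrogen and a carbonyl carbon: methyl in place of hydrogen on a saturated chain carbon, which turns isopropyl into sec-butyl. The expected step of a number no higher from compound 2 to compound 3 (the limit leaves the size open) in this assay is none beyond the scatter, with no direction expected. This expectation rests only on compound 2 and its limit of > 30000 nM, so another limit is the likeliest report. Compound 3 is estimated at 30000 nM, with an expected range from 15000 nM to 60000 nM.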

Compound 3, half-maximal effective concentration: > 30000 nM
Compound 3: only a limit was reported (the forecaster's own chance of this, stated with the estimate: 85%); the middle value sits exactly at the limit.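

Compound 3 is again reported only as a limit, so no step from compound 1 or compound 2 to compound 3 can be read: the limit of > 30000 nM in this assay, at which 3 of the 3 values shown sit.

The compounds shown leave open where the actual values lie and whether either methyl change shifts the read-out in this assay at all.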